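Hydroxy for fluoro on the aryl ring of compound 3

The compounds below may be only part of what the source reports. "The series", "measured", "known", "first", "only" and "open" are said of these compounds alone.

Measured so far:
compound 1 `C=CC[C@H]1C[C@]2([C@@H](C)Cc3cc(OC)c(OC)cc3F)OCOC2=CC1=O` — 14 nM
compound 2 `C=CC[C@H]1C[C@]2([C@@H](C)Cc3cc(C)c(OC)cc3F)OCOC2=CC1=O` — 230 nM
compound 3 `C=CC[C@H]1C[C@]2([C@@H](C)Cc3cc(F)c(OC)cc3F)OCOC2=CC1=O` — 30 nM

The three compounds share one core and differ only in a single substituent on the aromatic ring. In a functional assay on M14 cells (Homo sapiens) for antiproliferative activity, with a stated time of 72 h (a higher number here means a weaker inhibitor, a lower number a stronger inhibitor), compound 1 gives 14 nM, compound 3 gives 30 nM and compound 2 gives 230 nM. Compound 3 therefore stands in the middle: the step of a 2.1-fold higher number from compound 1 to compound 3 (0.33 log units; beyond the scatter) is modest, whereas the step of a 7.7-fold lower number from compound 2 to compound 3 (0.88 log units; beyond the scatter) is larger, and the step of a 16-fold higher number from compound 1 to compound 2 (1.22 log units; beyond the scatter) is the largest change in the set.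

Compound 4 `C=CC[C@H]1C[C@]2([C@@H](C)Cc3cc(O)c(OC)cc3F)OCOC2=CC1=O` is not yet measured. It differs from compound 3 by hydroxy in place of fluoro on an aromatic carbon. Within the data shown here, two measured steps bear on this exchange. The exchange of a methoxy for a fluoro at this carbon cost only a little, as shown by a 2.1-fold higher number from compound 1 to compound 3 (0.33 log units; beyond the scatter), while a methyl at the same carbon cost much more, as shown by a 16-fold higher number from compound 1 to compound 2 (1.22 log units; beyond the scatter). An oxygen-bearing group therefore appears tolerated at this carbon. For compound 4 the expected step of a 1.5-fold lower number from compound 3 to compound 4 (0.18 log units; within the scatter) is small, most likely within the scatter or a slight improvement. Compound 4 is estimated at 20 nM in this assay, with a range from 6 nM to 70 nM.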

Compound 4, half-maximal inhibitory concentration: 9 nM
The estimate for compound 4 lay 2.2-fold (0.35 log units) above the measured number, within the range that was stated.
By their numbers in this assay, from the lowest: compounds 4 and 1 (each within the scatter of the next); then compound 3; then compound 2.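

In this assay compound 4 shows that the methyl on the oxygen at this aromatic carbon can go without a measurable change, since the step from methoxy to hydroxy (a 1.6-fold lower number from compound 1 to compound 4 (0.19 log units; within the scatter)) is the only one at this carbon that does not exceed the scatter. Hydroxy also separates clearly from the two groups without oxygen, fluoro (a 3.3-fold lower number from compound 3 to compound 4 (0.52 log units; beyond the scatter)) and methyl (a 26-fold lower number from compound 2 to compound 4 (1.41 log units; beyond the scatter)), so among these four compounds the two groups attached through oxygen, hydroxy and methoxy, both give lower numbers than fluoro and methyl, with no compound going against this. No measurement is at hand that would explain this order.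

The compounds shown leave open whether oxygen itself is what matters at this carbon, which an amine, a carboxylic acid or a longer chain on the oxygen, such as ethoxy, would begin to test. They also leave open whether hydroxy would be tolerated in the same way if the methoxy group ortho to this carbon were replaced by an ethoxy group or a hydrogen.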